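Benzyl variation on a shared dihydroxyheptanoate core

The source may report more compounds than this note shows. Statements on the series, on what has been measured and on what is new or still open speak of the compounds shown alone.

Three compounds share one core and differ only in the aryl group on a saturated chain carbon bound to an amide-type nitrogen. Compound 1 `Cc1ccccc1CNC(=O)c1nc(-c2ccc(F)cc2)n(CC[C@@H](O)C[C@@H](O)CC(=O)O)c1C1CC1` gives 4.9 nM in an assay on microsomes from liver for inhibition of 3-hydroxy-3-methylglutaryl-coenzyme A reductase (Rattus norvegicus), read by scintillation counting, with stated times of 0.5 h and 0.75 h; a lower number here means a stronger inhibitor, a higher number a weaker inhibitor. Compound 2 `COc1ccc(CNC(=O)c2nc(-c3ccc(F)cc3)n(CC[C@@H](O)C[C@@H](O)CC(=O)O)c2C2CC2)cc1F` gives 3.7 nM in this assay. Going by the values given here, compound 3 `O=C(O)C[C@H](O)C[C@H](O)CCn1c(-c2ccc(F)cc2)nc(C(=O)NCc2ccc(F)cc2)c1C1CC1` gives 3.4 nM in this assay; its number is the lowest of the three, but the steps of a 1.4-fold lower number from compound 1 to compound 3 (0.16 log units; within the scatter) and a 1.1-fold lower number from compound 2 to compound 3 (0.04 log units; within the scatter) both lie within the scatter, as does a 1.3-fold lower number from compound 1 to compound 2 (0.12 log units; within the scatter), so no compound can be set apart from the others on these numbers.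

Compound 4 `COc1cccc(CNC(=O)c2nc(-c3ccc(F)cc3)n(CC[C@@H](O)C[C@@H](O)CC(=O)O)c2C2CC2)c1` is the next variation: 3-methoxyphenyl in place of 4-fluorophenyl on a saturated chain carbon bound to an amide-type nitrogen. Every step measured so far at this place, from 2-methylphenyl to 3-fluoro-4-methoxyphenyl, from 2-methylphenyl to 4-fluorophenyl, and from 3-fluoro-4-methoxyphenyl to 4-fluorophenyl, stayed within the scatter, so the aryl substituent has not shifted the number in any direction that could be read. On that basis the step of a 1.2-fold higher number from compound 3 to compound 4 (0.09 log units; within the scatter) is expected to stay within the scatter as well. Compound 4 is therefore estimated at 4.2 nM in this assay, with a range from 2 nM to 9 nM.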

Compound 4, half-maximal inhibitory concentration: 1.2 nM
The estimate for compound 4 lay 3.5-fold (0.54 log units) above the measured number, and the stated range ends above it.
By their numbers in this assay, from the lowest: compound 4; then compounds 3, 2 and 1 (each within the scatter of the next).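

Going by these compounds alone, compound 4 is the first at this place to move the number beyond the scatter in this assay: 3-methoxyphenyl gives a 2.8-fold lower number from compound 3 to compound 4 (0.45 log units; beyond the scatter), a 3.1-fold lower number from compound 2 to compound 4 (0.49 log units; beyond the scatter) and a 4.1-fold lower number from compound 1 to compound 4 (0.61 log units; beyond the scatter), each modest in size, and this makes compound 4 the strongest inhibitor of the four. The aryl group at this place can therefore shift the number after all, though the effect does not follow from the presence of a methoxy group alone: compound 2, with 3-fluoro-4-methoxyphenyl, also carries one and stays within the scatter of compounds 1 and 3. No measurement at hand gives a reason for this shift.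

The compounds shown leave open whether the lower number depends on the methoxy group itself, or whether 3-hydroxyphenyl, 3-ethoxyphenyl or 3-methylphenyl would stand with compound 4 or with the other three. They also leave open how 4-methoxyphenyl or plain phenyl would compare, so the part played by the fluorine in compound 2 cannot be separated from that of its methoxy group.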